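Moving the Chlorine on the Phenyl Ring and Cell Toxicity

This account rests on a few compounds, and the source may have more. Where it says the series, first, only, none or still open, it means among the compounds named here.

Compound 1 `O=c1[nH]cc(S(=O)(=O)Nc2ccccc2-c2cn(-c3ccccc3Cl)nn2)c(=O)[nH]1` gives 20800 nM. Compound 2 `O=c1[nH]cc(S(=O)(=O)Nc2ccccc2-c2cn(-c3cccc(Cl)c3)nn2)c(=O)[nH]1` reaches only the limit of the measurement, > 100000 nM. Compound 3 `O=c1[nH]cc(S(=O)(=O)Nc2ccc(-c3cn(-c4ccccc4Cl)nn3)cc2)c(=O)[nH]1` gives 16400 nM.

These values come from an ADME assay on GES1 cells (Homo sapiens) for cytotoxicity, read by MTT assay, with a stated time of 24 h; on this read-out higher numbers stand for lower toxicity in this test and lower numbers for higher toxicity in this test. The change 3-chlorophenyl in place of 2-chlorophenyl on an aromatic nitrogen produced an at least 4.8-fold higher number from compound 1 to compound 2 (0.68 log units; beyond the scatter); the step is given only as a lower bound because compound 2 sits at the limit of > 100000 nM in this assay, at which 1 of the 3 values shown sits. Compound 3 and compound 1 differ in their cores, and that difference is not broken down here. Compound 4 `O=c1[nH]cc(S(=O)(=O)Nc2ccc(-c3cn(-c4cccc(Cl)c4)nn3)cc2)c(=O)[nH]1` carries the same change as compound 3 does against its partner: 3-chlorophenyl in place of 2-chlorophenyl on an aromatic nitrogen. Since the place of the change is the same in both pairs, compound 4 is expected to show a step of a 6.1-fold higher number from compound 3 to compound 4 (0.79 log units; beyond the scatter), resting on compound 1 to compound 2 giving an at least 4.8-fold higher number from compound 1 to compound 2 (0.68 log units; beyond the scatter). Compound 4 is therefore estimated at 100000 nM, within 30000 nM to 300000 nM, and may well reach only the limit of this assay.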

Compound 4, half-maximal cytotoxic concentration: 7570 nM
Estimate against measurement, compound 4: 13-fold (1.12 log units) above, outside the stated range (below it).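

On the core of compound 3, the move from 2-chlorophenyl to 3-chlorophenyl gives a 2.2-fold lower number from compound 3 to compound 4 (0.34 log units; beyond the scatter), so in this assay the change does not carry over between the two cores, not even in direction: the same change on two cores in this assay, an at least 4.8-fold higher number (0.68 log units; beyond the scatter) from compound 1 to compound 2 and a 2.2-fold lower number (0.34 log units; beyond the scatter) from compound 3 to compound 4, at least 10-fold (1.01 log units) apart, beyond the scatter of two such steps.

Compound 2 gives > 100000 nM, which is a limit of the assay and not a number. This result rests on two pairs only, and it does not show why the cores differ or how any other change would behave on them.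

From the compounds shown here alone, it remains open whether a methoxy group or a nitrile in place of the chlorine would move the numbers the same way on both cores. A plain phenyl without chlorine, as a reference on each core, is open as well.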